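A few compounds are considered here, and "the series" means these few. Any claim that something is new, unique, unknown or untested is made for them only; others in the source may bear on it.

Working notes on the series, read in an ADME assay on microsomes from liver (Homo sapiens) for metabolic stability, read by LC-MS, with a stated time of 10 min; a higher number here means that more of the compound is left, a lower number that less of the compound is left. Compound 1 `Cc1cnc(CN(C)C[C@H]2Cc3c(cccc3N3CCNCC3)CN2)c(C)c1` has the entry "not determined" (no result reported), so it offers no number for comparison. Compound 2 `CN(C[C@@H]1Cc2c(cccc2N2CCNCC2)CN1)[C@H]1CCCc2cccnc21` gives 94.2%, and compound 3 `CN(C[C@H]1Cc2c(cccc2N2CCN(Cc3ccccn3)CC2)CN1)[C@H]1CCCc2cccnc21` gives 4.2%. Compound 3 therefore holds the lower of the two numbers, and the gap to compound 2 lies beyond the scatter. These two compounds differ in more than one place, so their values show a range for the series but no effect of a single change.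

Compound 4 `CCN1CCN(c2cccc3c2C[C@H](CN(C)[C@H]2CCCc4cccnc42)NC3)CC1` is the next comparison with compound 3. The change is methyl in place of pyridin-2-yl on a saturated chain carbon bound to an amine nitrogen in a ring, in words methyl in place of pyridin-2-yl on a saturated chain carbon bound to an amine nitrogen in a ring. Among the measured compounds shown here, no measured single-place step is available to calibrate this change, so the expectation is only loosely bounded. With compound 3 at 4.2% little of the compound is left, so the only sizeable movement open is upward. The expected change is a number 30.8 percentage points higher from compound 3 to compound 4 (beyond the scatter), a rise beyond the scatter. For compound 4 the estimated value in this assay is 35%, with an expected range of 12% to 70%.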

Compound 4, percent of the compound remaining: 0%
The estimate for compound 4 lay 35 percentage points above the measured number; the measured number lies below the stated range.
By their numbers in this assay, from the lowest: compounds 4 and 3 (each within the scatter of the next); then compound 2.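

In this assay the new step reads a number 4.2 percentage points lower from compound 3 to compound 4 (within the scatter), so methyl in place of pyridin-2-yl on a saturated chain carbon bound to an amine nitrogen in a ring, which is (pyridin-2-yl)methyl to ethyl when cut one bond further out, does not separate the two compounds. At this place, therefore, the aromatic ring is not needed for a low number: compound 4, with no ring in the entering group, gives 0%, and little room remains in which a further change towards less compound left could be read. Nothing measured on these compounds accounts for this result.

Going by these compounds, whether a different group at this place, such as a carboxylic acid or a hydroxyethyl chain, would give a number beyond the scatter of these two stays open. This single step also leaves open how other changes to the shared core would read.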